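The source may report more compounds than this note shows. Statements on the series, on what has been measured and on what is new or still open speak of the compounds shown alone.

Measured so far:
compound 1 `O=C(Nc1cccc(-c2oc3cc(-c4ccc(F)cc4)ccc3c(=O)c2O)c1)c1ccc(F)cc1` — 16000 nM
compound 2 `Cc1ccc(C(=O)Nc2cccc(-c3oc4cc(-c5ccc(F)cc5)ccc4c(=O)c3O)c2)cc1` — 4350 nM

In a functional assay on MDA-MB-231 cells (Homo sapiens) for antiproliferative activity, read by CCK-8 assay, with a stated time of 72 h (a higher number here means a weaker inhibitor, a lower number a stronger inhibitor), compound 1 gives 16000 nM, the highest of the two numbers; compound 2 sits a 3.7-fold lower number from compound 1 to compound 2 (0.57 log units; beyond the scatter) away. Compound 3 `COc1ccccc1C(=O)Nc1cccc(-c2oc3cc(-c4ccc(F)cc4)ccc3c(=O)c2O)c1` differs from compound 1 by 2-methoxyphenyl in place of 4-fluorophenyl on a carbonyl carbon. For the measured compounds named here, the one measured step touching the same part of the molecule, a 3.7-fold lower number from compound 1 to compound 2 (0.57 log units; beyond the scatter), swapped a substituent on that ring, so a change of similar, modest size is expected for compound 3, again toward a lower number, though a different group is introduced here. Compound 3 is therefore estimated at 7000 nM, within 2500 nM to 20000 nM, a step of a 2.3-fold lower number from compound 1 to compound 3 (0.36 log units; beyond the scatter).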

Compound 3, half-maximal inhibitory concentration: 5110 nM
Estimate against measurement, compound 3: 1.4-fold (0.14 log units) above, within the range that was stated.
By their numbers in this assay, from the lowest: compounds 2 and 3 (each within the scatter of the next); then compound 1.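

In this assay, 2-methoxyphenyl in place of 4-fluorophenyl on the carbonyl carbon gives a 3.1-fold lower number from compound 1 to compound 3 (0.50 log units; beyond the scatter) as its step, so a second replacement of that group also lowers the number. Compared with the 4-methylphenyl group of compound 2, the result is a 1.2-fold higher number from compound 2 to compound 3 (0.07 log units; within the scatter) and leaves these two groups indistinguishable in this assay. No available evidence accounts for either step.
Still open, as far as these compounds go, is whether other groups would lower the number in the same way. An amine or a carboxylic acid on this ring, or a longer chain in its place, would test this.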